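The compounds below may be only part of what the source reports. "The series", "measured", "known", "first", "only" and "open" are said of these compounds alone.

Measured compounds:
compound 1, `COc1ccc(C(=O)/C=C/c2ccc(N(C)C)cc2)c2c1C=CC(C)(C)O2`: 2750 nM
compound 2, `COc1ccc(C(=O)/C=C/c2cccc3ccccc23)c2c1C=CC(C)(C)O2`: > 10000 nM

Among the measured compounds shown here, in a functional assay on SK-OV-3 cells (Homo sapiens) for antiproliferative activity, read by MTT assay, with a stated time of 24 h (on this read-out lower numbers stand for stronger inhibition and higher numbers for weaker inhibition), compound 1 gives 2750 nM, the only number in this small set. For compound 2 the entry is > 10000 nM, which is a limit of the assay and not a number. Compound 1 thus stands alone as a measured point; the other entry sits at the limit of > 10000 nM in this assay, at which 1 of the 2 values shown sits. For the measured compounds named here, no pair of measured compounds differs in a single place, so no measured step exists to anchor the size of a change on the chain-bound ring.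

Compound 3, `COc1ccc(C(=O)/C=C/c2cccc(O)c2)c2c1C=CC(C)(C)O2`, is the compound to be measured. It differs from compound 1 in one place: 3-hydroxyphenyl in place of 4-(dimethylamino)phenyl on a double-bonded chain carbon bound to a double-bonded chain carbon. Going by the values given here, with no measured step of this kind to lean on, the expectation rests on compound 1 alone and is held loosely: a step toward weaker inhibition in this assay, somewhat beyond the scatter, with a real chance that only a limit is reported. The expected step is a 2.4-fold higher number from compound 1 to compound 3 (0.37 log units; beyond the scatter). For compound 3 the estimate in this assay is 6500 nM, with a range from 2500 nM to 15000 nM.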

Compound 3, half-maximal inhibitory concentration: > 10000 nM
Compound 3: only a limit was reported (the forecaster's own chance of this, stated with the estimate: 40%); middle value at least 1.5-fold (0.18 log units) away from the limit.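

Compound 3 reads > 10000 nM in this assay, which is a limit of the assay and not a number. Among the compounds shown here, replacing 4-(dimethylamino)phenyl with 3-hydroxyphenyl on a double-bonded chain carbon bound to a double-bonded chain carbon gives the first readable step at this place, an at least 3.6-fold higher number from compound 1 to compound 3 (0.56 log units; beyond the scatter), so activity on the shared core responds to this exchange, although the size of the step is only a lower bound. Compound 1 remains the only compound here with a number, and the series now presses against the ceiling of the read-out: the limit of > 10000 nM in this assay, at which 2 of the 3 values shown sit.

The exchange alters both the substituent and its location on the ring, so the compounds shown cannot separate the loss of dimethylamino from the arrival of hydroxy; 4-hydroxyphenyl or 3-(dimethylamino)phenyl at this place would divide the two. On these data alone, whether any group can improve on compound 1 also stays open, for example a phenyl ring carrying a morpholine or a carboxylic acid, and how far compound 3 lies past its limit cannot be read.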